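Swapping the Ether Tail for a Direct Phenyl Ring

A few compounds are considered here, and "the series" means these few. Any claim that something is new, unique, unknown or untested is made for them only; others in the source may bear on it.

Measured so far:
compound 1 `NC(=O)N(O)CC1=Cc2cc(OCC3CCCCC3)ccc2OC1` — 1390 nM
compound 2 `NC(=O)N(O)CC1=Cc2cc(OCCCc3ccccc3)ccc2OC1` — 160 nM

In an assay (Cavia porcellus) for inhibition of Polyunsaturated fatty acid 5-lipoxygenase (Homo sapiens) (on this read-out higher numbers stand for weaker inhibition and lower numbers for stronger inhibition), compound 1 gives 1390 nM, the highest of the two numbers; compound 2 sits an 8.7-fold lower number from compound 1 to compound 2 (0.94 log units; beyond the scatter). Compound 3 `NC(=O)N(O)CC1=Cc2cc(-c3ccccc3)ccc2OC1` changes compound 1 by phenyl in place of cyclohexylmethoxy on an aromatic carbon. For the measured compounds named here, the only measured step shows that an aromatic ring in the tail went with a stronger result, but compound 3 also drops the linking chain and ether oxygen, for which nothing has been measured. A modest step is therefore expected, with the direction uncertain, and compound 3 is estimated at 900 nM, ranging from 200 nM to 4000 nM, which would mean a 1.5-fold lower number from compound 1 to compound 3 (0.19 log units; within the scatter).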

Compound 3, half-maximal inhibitory concentration: 230 nM
Beside the measured number, compound 3's estimate is 3.9-fold (0.59 log units) above it; low and high end bracket the measured number.
By their numbers in this assay, from the lowest: compounds 2 and 3 (each within the scatter of the next); then compound 1.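

In this assay, replacing cyclohexylmethoxy with a phenyl ring attached directly to the aromatic carbon gives a 6.0-fold lower number from compound 1 to compound 3 (0.78 log units; beyond the scatter). The ether oxygen and linking carbon of compound 1 are therefore not needed for a lower number at this position. No available evidence explains the drop.

From the compounds shown here alone, the ring type, the oxygen and the linking carbon all change together in this step, so their separate contributions remain open. A benzyloxy group, which has an aromatic ring and keeps the oxygen and linking carbon, would help separate them.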